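A few compounds are considered here, and "the series" means these few. Any claim that something is new, unique, unknown or untested is made for them only; others in the source may bear on it.

Measured so far in a functional assay on ECa-109 cells for inhibition, with ECa-109 cell line (Homo sapiens) as the target, read by sulforhodamine B assay; a lower number here means a stronger inhibitor, a higher number a weaker inhibitor:

Compound 1, `O=C1C=C(Nc2ccc(I)cc2)C(=O)c2c1nc1n2[C@H]2OC[C@@H](O)[C@H]2OC1`, gives 2300 nM.
Compound 2, `O=C1C(Nc2cccc(Cl)c2)=CC(=O)c2c1nc1n2[C@H]2OC[C@@H](O)[C@H]2OC1`, gives 3080 nM.
Compound 3, `O=C1C(N2CCCCC2)=CC(=O)c2c1nc1n2[C@H]2OC[C@@H](O)[C@H]2OC1`, reaches only a limit of the assay, reported as > 8000 nM.

Compound 1 stands at the lowest of the two numbers; compound 2 lies within the usual scatter of it, so no order between the two can be read. Within the data shown here, the one step that changes a single place is an at least 2.5-fold higher number from compound 2 to compound 3 (0.41 log units; beyond the scatter), where the value of compound 3 sits at the limit of > 8000 nM in this assay, at which 1 of the 3 values shown sits, so the step can only be given as a lower bound.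

Compound 4, `O=C1C=C(NCc2ccccc2)C(=O)c2c1nc1n2[C@H]2OC[C@@H](O)[C@H]2OC1`, has not yet been measured in this assay. It differs from compound 1 as benzyl in place of 4-iodophenyl on an amine nitrogen. The step from compound 2 to compound 3 bears on this only loosely: there an aromatic amino substituent on the core was traded for a saturated ring closed onto the nitrogen, and the number rose at least modestly. In compound 4 the nitrogen keeps its hydrogen and the aromatic ring is held one carbon further out, so a smaller movement in the same direction is expected. Compound 4 is estimated at 4500 nM, with a range from 1800 nM to 12000 nM, meaning an expected step of a 2.0-fold higher number from compound 1 to compound 4 (0.29 log units; within the scatter).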

Compound 4, half-maximal inhibitory concentration: > 8000 nM
Compound 4 was reported as a limit; the forecaster's own chance of this, stated with the estimate: 15%; middle value at least 1.7-fold (0.24 log units) from the limit.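

Changing (4-iodophenyl)amino to benzylamino gives an at least 3.4-fold higher number from compound 1 to compound 4 (0.54 log units; beyond the scatter) in this assay, and this shows something the earlier step could not: on this amine nitrogen, keeping both the amine hydrogen and an aromatic ring is not enough to hold the number near that of compound 1, whereas piperidin-1-yl in compound 3 had lost both of these features together. As far as these compounds go, compound 4 reaches only a limit of the assay, > 8000 nM, so the step is a lower bound and its full size remains unknown. Compound 3 and compound 4 now rest at the same limit, so no order between the two can be read: the limit of > 8000 nM in this assay, at which 2 of the 4 values shown sit.

The change from compound 1 to compound 4 removes the iodine and inserts a carbon link before the ring in a single move, so the compounds shown do not tell which of the two accounts for the rise. A plain phenyl group or a 4-iodobenzyl group on the same amine nitrogen would separate these two parts of the change.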